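Chloro for Methoxy on Two Related Cores

The compounds below may be only part of what the source reports. "The series", "measured", "known", "first", "only" and "open" are said of these compounds alone.

Compound 1 `COc1ccc(CN2CCCCC2CCOc2ccc(-c3nc4cc(C(N)=O)ccc4[nH]3)cc2)cc1` and compound 2 `NC(=O)c1ccc2[nH]c(-c3ccc(OCCC4CCCCN4Cc4ccc(Cl)cc4)cc3)nc2c1` share one core, while compound 3 `COc1ccc(CN2CCC(CCOc3ccc(-c4nc5cc(C(N)=O)ccc5[nH]4)cc3)CC2)cc1` and compound 4 `NC(=O)c1ccc2[nH]c(-c3ccc(OCCC4CCN(Cc5ccc(Cl)cc5)CC4)cc3)nc2c1` share another; how the two cores differ is not broken down here. In a physicochemical assay for solubility, with a stated time of 3 days, at pH 7 (on this read-out lower numbers stand for lower solubility and higher numbers for higher solubility), compound 1 gives 84000 nM, and compound 2 gives 115000 nM. The change between them chloro in place of methoxy on an aromatic carbon made a step of a 1.4-fold higher number from compound 1 to compound 2 (0.14 log units; within the scatter). For compound 3 this assay reports only a limit, < 1000 nM. Compound 4 carries the same change (chloro in place of methoxy on an aromatic carbon), set at a place described in the same words. Beside the measured 1.4-fold higher number from compound 1 to compound 2 (0.14 log units; within the scatter), the expected step is a step that the limit leaves unreadable from compound 3 to compound 4, because compound 3 already sits at the limit of < 1000 nM in this assay, at which 1 of the 3 values shown sits, and the one measured instance stayed within the scatter. The estimate for compound 4 is 800 nM, with a range from 200 nM to 2000 nM, and most likely again only a limit is reported.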

Compound 4, solubility: 2000 nM
The estimate for compound 4 lay 2.5-fold (0.40 log units) below the measured number, within the range that was stated.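

In this assay, chloro in place of methoxy on an aromatic carbon gives an at least 2.0-fold higher number from compound 3 to compound 4 (0.30 log units; that floor lies within the scatter), and on the other core the same change gives a 1.4-fold higher number from compound 1 to compound 2 (0.14 log units; within the scatter). The number therefore did not fall with this change on either core, but neither step is shown to lie beyond the scatter, so no shared effect of the change is established. The full size of the step on the second core cannot be read because compound 3 is reported only as a limit: the limit of < 1000 nM in this assay, at which 1 of the 4 values shown sits.

The compounds shown leave open whether the two cores would also track each other with other groups in place of the chloro, such as fluoro, nitrile or a dimethylamino group. They also leave open whether the 4-chlorobenzyl group would give a step of similar size on further cores.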